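The source may hold more compounds than are shown below. What is called first, only, known or untested is meant among the compounds shown, and "the series" means these compounds.

Measured so far in a physicochemical assay for solubility, read by HPLC; on this read-out higher numbers stand for higher solubility and lower numbers for lower solubility:
- compound 1 `O=C(CC1CCCCC1)N1CCN(c2nc(=O)c3cc(C(F)(F)F)cc([N+](=O)[O-])c3s2)CC1`: 0.12 ug/mL
- compound 2 `Cc1ccc(C(=O)N2CCN(c3nc(=O)c4cc(C(F)(F)F)cc([N+](=O)[O-])c4s3)CC2)cc1`: 6.7 ug/mL
- compound 3 `O=C(C1CC1)N1CCN(c2nc(=O)c3cc(C(F)(F)F)cc([N+](=O)[O-])c3s2)CC1`: 52.9 ug/mL

Compound 3 stands highest of the three numbers in this assay; its nearest neighbour is compound 2 (a 7.9-fold higher number from compound 2 to compound 3 (0.90 log units; beyond the scatter)) and the furthest is compound 1 (a 440-fold higher number from compound 1 to compound 3 (2.64 log units; beyond the scatter)). Compound 4 `CCC(C)C(=O)N1CCN(c2nc(=O)c3cc(C(F)(F)F)cc([N+](=O)[O-])c3s2)CC1` differs from compound 3 in one place: sec-butyl in place of cyclopropyl on a carbonyl carbon. Both measured steps that end at compound 3 bear on this change, as each replaces a larger carbonyl substituent with cyclopropyl and both run upward, one large (a 440-fold higher number from compound 1 to compound 3 (2.64 log units; beyond the scatter)) and one modest (a 7.9-fold higher number from compound 2 to compound 3 (0.90 log units; beyond the scatter)). Sec-butyl sits, by heavy-atom count, between cyclopropyl and the two substituents that gave the lower numbers, so the step from compound 3 to compound 4 is expected to run downward and to be beyond the scatter, as an 8.8-fold lower number from compound 3 to compound 4 (0.95 log units; beyond the scatter). On that reading compound 4 is estimated at 6 ug/mL in this assay, with a range of 1 ug/mL to 30 ug/mL.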

Compound 4, solubility: 104 ug/mL
Compound 4: the middle estimate sits 17-fold (1.24 log units) below what was measured, outside the stated range (above it).
By their numbers in this assay, from the lowest: compound 1; then compound 2; then compounds 3 and 4 (each within the scatter of the next).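

Working notes: in this assay, sec-butyl in place of cyclopropyl on a carbonyl carbon gives a 2.0-fold higher number from compound 3 to compound 4 (0.29 log units; within the scatter) and so does not separate the two groups: the open chain and the three-membered ring read alike at this position. The other two steps stay large, with a 16-fold higher number from compound 2 to compound 4 (1.19 log units; beyond the scatter) and an 870-fold higher number from compound 1 to compound 4 (2.94 log units; beyond the scatter), so 4-methylphenyl and cyclohexylmethyl remain well apart from both small groups. Compound 4 goes against a simple ordering by heavy-atom count, and no measurement at hand accounts for this result.

Open, going by these compounds, is where along the size range the drop sets in, for instance with a longer chain such as n-hexyl or with a cyclopentyl ring. Also open, on these data alone, is how a carbonyl substituent carrying an amine or a carboxylic acid would read.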